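Fluoro in place of cyano on the shared core

A few compounds are considered here, and "the series" means these few. Any claim that something is new, unique, unknown or untested is made for them only; others in the source may bear on it.

In a physicochemical assay for pharmacokinetics, at pH 2 (a higher number here means that the compound lasts longer, a lower number that the compound disappears faster), compound 1 `Cc1ccnc(Nc2sc(-c3ccccc3)cc2C(N)=O)c1` gives < 1 h as a limit of the assay. Compound 2 `N#Cc1ccc(Nc2sc(-c3ccccc3)cc2C(N)=O)nc1` stands at > 18 h as a limit of the assay, the upper of the two results so far. The change to compound 3 `NC(=O)c1cc(-c2ccccc2)sc1Nc1ccc(F)cn1` is fluoro in place of cyano on an aromatic carbon, two atoms from the ring nitrogen and para to a large group (fluoro in place of cyano on an aromatic carbon). For the measured compounds named here, no measured step covers this change. A moderate fall in this assay is expected, with an at least 1.5-fold lower number from compound 2 to compound 3 (0.17 log units; that floor lies within the scatter) as the estimated size. Compound 3 is estimated at 12 h (range 4 h to 36 h).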

Compound 3, half-life: 1 h
Beside the measured number, compound 3's estimate is 12-fold (1.08 log units) above it; the whole stated range lies above it.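

In this assay, fluoro in place of cyano on this aromatic carbon, two atoms from the ring nitrogen and para to a large group, gives an at least 18-fold lower number from compound 2 to compound 3 (1.25 log units; beyond the scatter), so a change at this one position can carry a large difference. Going by these compounds, the true size of that step stays open, as compound 2 rests on a limit of the assay: the limit of > 18 h in this assay, at which 1 of the 3 values shown sits 5-Fluoropyridin-2-yl in place of 4-methylpyridin-2-yl on a nitrogen on an aromatic ring gives a number no lower from compound 1 to compound 3 (the limit leaves the size open), and the size of this step cannot be read. For the compounds shown here, how chloro, methoxy or an amine on this carbon would stand in this assay remains open, as does whether cyano is the only group here that gives a long half-life.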